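The source may report more compounds than this note shows. Statements on the series, on what has been measured and on what is new or still open speak of the compounds shown alone.

Measured so far in a functional assay on PANC-1 cells (Homo sapiens) for inhibition, read by MTT assay, with a stated time of 24 h; a higher number here means a weaker inhibitor, a lower number a stronger inhibitor:
- compound 1 `CC1(C)[C@H]2CC[C@]1(C)N(Cc1cn(-c3cccc(F)c3)nn1)C(=O)C2` gives 220 nM
- compound 2 `CC1(C)[C@H]2CC[C@]1(C)N(Cc1cn(-c3ccc(F)cc3)nn1)C(=O)C2` gives 110 nM
- compound 3 `CC1(C)[C@H]2CC[C@]1(C)N(Cc1cn(-c3ccccc3O)nn1)C(=O)C2` gives 230 nM

Compound 3 shares the upper end of these numbers with compound 1, as the data show a 1.0-fold higher number from compound 1 to compound 3 (0.02 log units; within the scatter). It stands apart only from compound 2, with a 2.1-fold higher number from compound 2 to compound 3 (0.32 log units; beyond the scatter).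

Compound 4 `COc1cccc(-n2cc(CN3C(=O)C[C@@H]4CC[C@@]3(C)C4(C)C)nn2)c1` has not yet been measured. It keeps the shared core and differs from compound 3 on one group: 3-methoxyphenyl in place of 2-hydroxyphenyl on an aromatic nitrogen. In words, this is 3-methoxyphenyl in place of 2-hydroxyphenyl on an aromatic nitrogen.

All three measured steps exchange one substituted phenyl group at this same place. Besides the two above, there is a 2.0-fold lower number from compound 1 to compound 2 (0.30 log units; within the scatter). Going by the values given here, only the step to compound 3 from compound 2 passes the scatter, and it is modest. Among the compounds with values here, no measured compound carries a 3-methoxyphenyl group, so the data offer no direct comparison. Compound 1, with its 3-fluorophenyl group, gives the nearest name match at 220 nM.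

No step beyond the scatter is therefore expected in this assay. The estimate amounts to a 1.2-fold lower number from compound 3 to compound 4 (0.06 log units; within the scatter), which is expected to stay within the scatter. Compound 4 is expected at about 200 nM, with an estimated range from 95 nM to 420 nM.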

Compound 4, half-maximal inhibitory concentration: 860 nM
For compound 4 the middle estimate is 4.3-fold (0.63 log units) below the measured one; the measured number lies above the stated range.
By their numbers in this assay, from the lowest: compounds 2, 1 and 3 (each within the scatter of the next, the first and the last beyond it); then compound 4.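

In this assay the change to the 3-methoxyphenyl group gives a 3.7-fold higher number from compound 3 to compound 4 (0.57 log units; beyond the scatter) and a 7.8-fold higher number from compound 2 to compound 4 (0.89 log units; beyond the scatter) and so moves the number further than any exchange among the three earlier phenyl groups on this aromatic nitrogen. The closest comparison is methoxy in place of fluoro on an aromatic carbon, with a 3.9-fold higher number from compound 1 to compound 4 (0.59 log units; beyond the scatter) showing that the 3-fluorophenyl and 3-methoxyphenyl groups do not read alike, so the number at this place depends on the group on the phenyl ring and not only on where the name places it. Nothing in the material shown gives a measured reason for this rise.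

Whether the rise belongs to methoxy wherever it stands on the phenyl ring stays open, since the compounds shown include neither a 2-methoxyphenyl nor a 4-methoxyphenyl group, and the hydroxy and fluoro compounds cannot separate the effect of the group from that of its place. They also leave open how an unsubstituted phenyl, an ethoxy group, an amine or a carboxylic acid on the phenyl ring would read in this assay.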